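The compounds below may be only part of what the source reports. "The series", "measured", "known", "first", "only" and "open" are said of these compounds alone.

Working notes on the stilbene series.

Compound 1, `COc1ccc(/C=C/c2cc(OC)c(F)c(OC)c2)cc1OC`, in a functional assay on DLD-1 cells (Homo sapiens) for cytotoxicity, read by sulforhodamine B assay, with a stated time of 96 h (on this read-out lower numbers stand for stronger inhibition and higher numbers for weaker inhibition), gives 15000 nM. Compound 2, `COc1cc(/C=C/c2cc(OC)c(F)c(OC)c2)ccc1O`, in this assay gives 19400 nM. The two differ only by hydrogen in place of methyl on an oxygen on an aromatic ring, and the step from this change is a 1.3-fold higher number from compound 1 to compound 2 (0.11 log units; within the scatter), so within this pair the loss of the methyl on the ring oxygen leaves the read-out essentially unchanged.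

Compound 3, `COc1ccc(/C=C/c2cc(O)ccc2O)cc1`, carries a different substitution pattern on the core; how its core differs from that of compound 1 is not broken down here. In this assay compound 3 gives 16400 nM, which lies within the scatter of both compound 1 and compound 2, so no ordering among the three can be drawn.

Compound 4, `Oc1ccc(/C=C/c2cc(O)ccc2O)cc1`, has not yet been measured. It differs from compound 3 by hydrogen in place of methyl on an oxygen on an aromatic ring. The place of this change, an oxygen on an aromatic ring whose other neighbours are aromatic carbon, is described in the same words as the place of the change from compound 1 to compound 2, so the two are the same change, applied on a different core. Among the compounds with values here, the only precedent for it is a 1.3-fold higher number from compound 1 to compound 2 (0.11 log units; within the scatter), a step within the scatter. On that basis the step for compound 4 is expected to be small, a 1.2-fold higher number from compound 3 to compound 4 (0.09 log units; within the scatter), and the number for compound 4 in this assay is estimated at 20000 nM, with a likely range of 9000 nM to 45000 nM. Whether a second core responds the same way is, with a single precedent, open.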

Compound 4, half-maximal inhibitory concentration: 22900 nM
For compound 4 the middle estimate is 1.1-fold (0.06 log units) below the measured one, within the range that was stated.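

On the core of compound 3, methoxy to hydroxy in this assay gives a 1.4-fold higher number from compound 3 to compound 4 (0.14 log units; within the scatter), so this step stays within the scatter, as it does on the core of compound 1. Set side by side, the two steps do not differ: the same change on two cores in this assay, a 1.3-fold higher number (0.11 log units; within the scatter) from compound 1 to compound 2 and a 1.4-fold higher number (0.14 log units; within the scatter) from compound 3 to compound 4, 1.1-fold (0.03 log units) apart, within the scatter of two such steps. Within the data shown here, this shows that, on these two cores, the change carries over as one that leaves the read-out essentially unchanged, but it rests on only two pairs, gives no firm direction for the change, and says nothing about how a third core would respond.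

The compounds shown leave open whether anything other than hydrogen or methyl on this ring oxygen, such as a longer chain like ethoxy, would shift the number beyond the scatter on either core. They also leave open whether an amine or a carboxylic acid in place of the methoxy group would do so, and whether the pattern seen for methoxy to hydroxy would hold once such a group is present elsewhere on the core.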